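Nitrostyryl-cyclohexanone series: para-substituent swap on the second aryl ring

The source may report more compounds than this note shows. Statements on the series, on what has been measured and on what is new or still open speak of the compounds shown alone.

Measured compounds:
- compound 1, `O=C1/C(=C/c2ccc(Cl)cc2)CCC/C1=C\c1cccc([N+](=O)[O-])c1`: 2300 nM
- compound 2, `CN(C)c1ccc(/C=C2\CCC/C(=C\c3cccc([N+](=O)[O-])c3)C2=O)cc1`: 71000 nM
- compound 3, `O=C1/C(=C/c2ccc(Cl)cc2)CCC/C1=C\c1ccc([N+](=O)[O-])cc1`: 2700 nM

In a functional assay on HSC-4 cells (Homo sapiens) for cytotoxicity, with a stated time of 24 h (on this read-out lower numbers stand for higher toxicity in this test and higher numbers for lower toxicity in this test), compound 1 gives 2300 nM and compound 3 gives 2700 nM; these two values lie within the scatter of each other, so no order between them can be read. The two have the same atoms joined differently; the difference between the two cores is not broken down here.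

Within the pairs that share a core, one change has been measured once. From compound 1 to compound 2, (dimethylamino in place of chloro on an aromatic carbon), and the step is a 31-fold higher number from compound 1 to compound 2 (1.49 log units; beyond the scatter). Compound 2 in this assay gives 71000 nM.

Compound 4, `CN(C)c1ccc(/C=C2\CCC/C(=C\c3ccc([N+](=O)[O-])cc3)C2=O)cc1`, has not been measured in this assay. Among the compounds with values here, it differs from compound 3 by dimethylamino in place of chloro on an aromatic carbon; the place lines of the two changes read the same word for word, so this is the same change as the one from compound 1 to compound 2. Within the data shown here, the step expected from compound 3 to compound 4 is estimated at a 30-fold higher number from compound 3 to compound 4 (1.47 log units; beyond the scatter), about the size of the measured one, because compound 1 and compound 3 start from values within the scatter of each other and the only measured instance of this change is a 31-fold higher number from compound 1 to compound 2 (1.49 log units; beyond the scatter). With one measured instance only, the expectation is correspondingly wide.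

Compound 4 is therefore expected to give 80000 nM in this assay, with the range 25000 nM to 250000 nM as the estimate.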

Compound 4, half-maximal cytotoxic concentration: > 400000 nM
Compound 4: only a limit was reported; the forecaster's own chance of this, stated with the estimate: 20%; middle value at least 5.0-fold (0.69 log units) from the limit.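

In this assay compound 4 gives > 400000 nM, which is a limit of the assay and not a number. Dimethylamino in place of chloro on the core of compound 3 gives an at least 140-fold higher number from compound 3 to compound 4 (2.17 log units; beyond the scatter), and the dimethylamino pair also separates by the place of the nitro group, with an at least 5.6-fold higher number from compound 2 to compound 4 (0.75 log units; beyond the scatter), although compound 1 and compound 3 lie within the scatter of each other. The change therefore keeps its direction on both cores but does not carry over at one size, while the full size of the step on the core of compound 3 and any reason for the gap remain unread: the same change on two cores in this assay, a 31-fold higher number (1.49 log units; beyond the scatter) from compound 1 to compound 2 and an at least 140-fold higher number (2.17 log units; beyond the scatter) from compound 3 to compound 4, at least 4.7-fold (0.68 log units) apart, beyond the scatter of two such steps.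

The compounds shown leave open whether this dependence on the core belongs to dimethylamino alone or also appears with other groups in the same place, such as a methoxy group, a primary amine or a carboxylic acid. They also leave open whether a nitrile in place of the nitro group would give the same gap between the two cores, and a series without a value at the limit would be needed to give that gap a definite size.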